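Oxalyl anilide series: ester to alanine amide on the para tail

A few compounds are considered here, and "the series" means these few. Any claim that something is new, unique, unknown or untested is made for them only; others in the source may bear on it.

The series shares an acetamidophenyl oxalamide core with a varied amide tail. In an assay on mitochondria from liver for inhibition of Amine oxidase [flavin-containing] A (Rattus norvegicus), with a stated time of 60 min (on this read-out lower numbers stand for stronger inhibition and higher numbers for weaker inhibition), compound 1 `CCOC(=O)c1ccc(NC(=O)C(=O)c2ccccc2NC(C)=O)cc1` gives 83 nM. Compound 2 `COC(=O)C[C@H](NC(=O)C(=O)c1ccccc1NC(C)=O)C(=O)OC` gives 58 nM and compound 3 `COC(=O)CCCCCNC(=O)C(=O)c1ccccc1NC(C)=O` gives 68 nM in this assay; all three numbers lie within the usual scatter of one another, so compound 1 stands level with the other two. Compound 4 `COC(=O)[C@H](C)NC(=O)c1ccc(NC(=O)C(=O)c2ccccc2NC(C)=O)cc1` differs from compound 1 by (1-(methoxycarbonyl)ethyl)amino in place of ethoxy on a carbonyl carbon. Going by the values given here, no measured pair in the set tracks this exact change. Since compound 2 with 58 nM and compound 3 with 68 nM stay close to compound 1 across quite different tails, the expected step of a 1.0-fold lower number from compound 1 to compound 4 (0.02 log units; within the scatter) is none beyond the scatter. Compound 4 is therefore estimated at 80 nM, with a range of 30 nM to 250 nM.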

Compound 4, half-maximal inhibitory concentration: 36 nM
Beside the measured number, compound 4's estimate is 2.2-fold (0.35 log units) above it; measured number inside the range.
By their numbers in this assay, from the lowest: compounds 4, 2, 3 and 1 (each within the scatter of the next, the first and the last beyond it).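

In this assay, going by these compounds alone, (1-(methoxycarbonyl)ethyl)amino in place of ethoxy on a carbonyl carbon gives a 2.3-fold lower number from compound 1 to compound 4 (0.36 log units; beyond the scatter), the only step read so far and a modest one. This position therefore tolerates the larger group, which brings one hydrogen-bond donor and one defined stereocentre, with no loss of inhibition. Nothing available explains the lower number.

Going by these compounds, it remains open whether a carboxylic acid in place of the methyl ester, or plain methylamino on that carbonyl carbon, would keep the lower number. On these data alone, the role of the defined stereocentre also remains open.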